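Amide nitrogen change from compound 3 to compound 4

The source may hold more compounds than are shown below. What is called first, only, known or untested is meant among the compounds shown, and "the series" means these compounds.

In a functional assay on the whole organism with Mus musculus as the target (a higher number here means that more compound is needed for the effect, a lower number that less compound is needed), compound 1 `NC(=O)/C=C/c1cccc(C(F)(F)F)c1` gives 37.5 mg/kg, compound 2 `O=C(/C=C/c1cccc(C(F)(F)F)c1)NCCO` gives 78.6 mg/kg and compound 3 `CCC(O)CNC(=O)/C=C/c1cccc(C(F)(F)F)c1` gives 87.5 mg/kg. Compound 3 therefore stands at the high end of these numbers, together with compound 2.

Compound 4 `CN1CCN(C(=O)/C=C/c2cccc(C(F)(F)F)c2)CC1` keeps the shared core and carries 4-methylpiperazin-1-yl in place of (2-hydroxybutyl)amino on a carbonyl carbon. Among the compounds with values here, no measured step makes this exact change. The closest evidence comes from the steps on the amide-type nitrogen, a 2.1-fold higher number from compound 1 to compound 2 (0.32 log units; beyond the scatter) and a 2.3-fold higher number from compound 1 to compound 3 (0.37 log units; beyond the scatter), both modest. Extending the chain gave a 1.1-fold higher number from compound 2 to compound 3 (0.05 log units; within the scatter). No ring at this position has been measured, so the range stays wide and no step beyond the scatter is expected in this assay, in either direction. The expected step is a 1.2-fold lower number from compound 3 to compound 4 (0.07 log units; within the scatter). For compound 4 the estimated value is 75 mg/kg, with an expected range of 35 mg/kg to 160 mg/kg.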

Compound 4, dose for half-maximal effect: > 100 mg/kg
Compound 4 gave a limit, no number; the forecaster's own chance of this, stated with the estimate: 15%; middle value at least 1.3-fold (0.12 log units) away from the limit.
By their numbers in this assay, from the lowest: compound 1; then compounds 2 and 3 (each within the scatter of the next). At a limit, above all of these: compound 4.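

The result for compound 4 in this assay is a limit, not a number: the limit of > 100 mg/kg in this assay, at which 1 of the 4 values shown sits.

Putting 4-methylpiperazin-1-yl in place of amino on the carbonyl carbon gives an at least 2.6-fold higher number from compound 1 to compound 4 (0.42 log units; beyond the scatter), so this ring, like the open chains, goes with a higher number than the amino group. Against the open chains, the floors of an at least 1.1-fold higher number from compound 3 to compound 4 (0.05 log units; that floor lies within the scatter) and an at least 1.2-fold higher number from compound 2 to compound 4 (0.10 log units; that floor lies within the scatter) lie within the scatter, so the size of these two steps cannot be read.

Still open, going by these compounds, is whether the higher number goes with the ring itself or with the loss of the amide hydrogen. A dimethylamino group or a morpholin-4-yl ring on the carbonyl carbon would help to separate these two changes.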